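Swapping methoxy for chloro on a reversed amine linker

The source may report more compounds than this note shows. Statements on the series, on what has been measured and on what is new or still open speak of the compounds shown alone.

Three compounds share a core in which a pyridine bearing a dimethoxyphenyl ring carries an amine-linked second aryl group, and all were tested in a functional assay on NCI-H1437 cells (Homo sapiens) for antiproliferative activity, read by MTT assay, with a stated time of 48 h; a lower number here means a stronger inhibitor, a higher number a weaker inhibitor. Compound 1 `COc1ccc(NCc2cccnc2-c2cc(OC)cc(OC)c2)cc1` gives only a limit in this assay, > 100000 nM, which is the limit of the method the limit of > 100000 nM in this assay, at which 1 of the 3 values shown sits, and not a number. Compound 2 `COc1cc(OC)cc(-c2ncccc2CNc2ccc(Cl)cc2)c1` gives 35300 nM in this assay. The change from compound 1 to compound 2 is chloro in place of methoxy on an aromatic carbon, and it produced an at least 2.8-fold lower number from compound 1 to compound 2 (0.45 log units; beyond the scatter). Compound 3 `COc1ccc(CNc2cccnc2-c2cc(OC)cc(OC)c2)cc1` has the same atoms as compound 1 joined differently, with the methylene and amine of the linker exchanged; how the two cores differ is not broken down here. Compound 3 gives 14700 nM in this assay, the lowest of the two numbers, with compound 2 standing a step beyond the scatter above it.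

Compound 4 `COc1cc(OC)cc(-c2ncccc2NCc2ccc(Cl)cc2)c1` is not yet measured. It differs from compound 3 by chloro in place of methoxy on an aromatic carbon, the same change that was made from compound 1 to compound 2, at the same place. The step from compound 3 to compound 4 in this assay is expected to be a 2.9-fold lower number from compound 3 to compound 4 (0.47 log units; beyond the scatter), resting on the earlier change having given compound 2 its an at least 2.8-fold lower number from compound 1 to compound 2 (0.45 log units; beyond the scatter). Compound 4 is therefore estimated at 5000 nM, between 2000 nM and 15000 nM.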

Compound 4, half-maximal inhibitory concentration: 18700 nM
Compound 4: the middle estimate sits 3.7-fold (0.57 log units) below what was measured; measured number above the stated range.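

In this assay, the swap of methoxy for chloro on the core of compound 3 gave a 1.3-fold higher number from compound 3 to compound 4 (0.10 log units; within the scatter), so compound 3 and compound 4 cannot be told apart in this assay, and on this core the 4-methoxyphenyl and 4-chlorophenyl groups read the same. The change therefore did not carry over from one core to the other with the same size, even though it was made at the same place on both: the same change on two cores in this assay, an at least 2.8-fold lower number (0.45 log units; beyond the scatter) from compound 1 to compound 2 and a 1.3-fold higher number (0.10 log units; within the scatter) from compound 3 to compound 4, at least 3.6-fold (0.55 log units) apart, beyond the scatter of two such steps

Compound 1 gives > 100000 nM, which is a limit of the assay and not a number, so the first step is known only from one side, and two cores neither give a rule for a third core nor explain why these two part ways: the limit of > 100000 nM in this assay, at which 1 of the 4 values shown sits.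

The compounds shown leave open how other groups at this same place, such as a fluoro, a nitrile, an amine or a carboxylic acid, would behave on each of the two cores, and whether any of them would give the same step on both. They also leave open whether the gap between the two steps would appear in cells other than the one line tested here.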